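The compounds below may be only part of what the source reports. "The series", "measured", "known", "first", "only" and "open" are said of these compounds alone.

Compound 2 `CC(c1cc2cccnc2cc1F)n1cnc2ncc(-c3cnn(C)c3)nc21` gives 31.3 nM in a functional assay on NCI-H1993 cells (Homo sapiens) for inhibition, read by CCK-8 assay, with a stated time of 72 h; a lower number here means a stronger inhibitor, a higher number a weaker inhibitor. Its core and that of compound 1 `CC(c1cc(F)c2ncccc2c1)n1cnc2ncc(-c3cnn(C)c3)nc21` are made of the same atoms joined differently, but the difference between the two cores is not broken down here. In this assay compound 1 gives > 10000 nM, which is a limit of the assay and not a number. Compound 3 `CC(c1cc(F)c2ncccc2c1)n1cnc2ncc(-c3cn[nH]c3)nc21` gives > 10000 nM in this assay, again a limit rather than a number. The change from compound 1 to compound 3 is hydrogen in place of methyl on an aromatic nitrogen, and its step, a step that the two limits leave unreadable from compound 1 to compound 3, cannot be read because of the limit of > 10000 nM in this assay, at which 2 of the 3 values shown sit. Compound 4 `CC(c1cc2cccnc2cc1F)n1cnc2ncc(-c3cn[nH]c3)nc21` carries the same change on the core of compound 2: hydrogen in place of methyl on an aromatic nitrogen. Since compound 1 and compound 3 both sit at the limit, the measured pair says nothing about the size of this step; the expected step from compound 2 to compound 4 in this assay, a 3.2-fold higher number from compound 2 to compound 4 (0.50 log units; beyond the scatter), rests only on the small size of the change. Compound 4 is therefore estimated at 100 nM, between 30 nM and 400 nM.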

Compound 4, half-maximal inhibitory concentration: 187 nM
The estimate for compound 4 lay 1.9-fold (0.27 log units) below the measured number; low and high end bracket the measured number.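

On the core of compound 2, replacing 1-methyl-1H-pyrazol-4-yl with 1H-pyrazol-4-yl weakens inhibition in this assay: a 6.0-fold higher number from compound 2 to compound 4 (0.78 log units; beyond the scatter). On the core of compound 1 the same change gives no size to set beside this one, and its step cannot be read because compound 1 and compound 3 both sit at a limit of the assay: the limit of > 10000 nM in this assay, at which 2 of the 4 values shown sit. The change therefore has a measured size on one core only, so the data do not show whether that size carries from one core to the other.

The compounds shown leave open what an ethyl group, a longer chain ending in an amine, or a carboxylic acid would do in place of the methyl on the core of compound 2. As far as these compounds go, whether any such group would bring the core of compound 1 to a readable number also remains open.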